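The source may report more compounds than this note shows. Statements on the series, on what has been measured and on what is new or still open speak of the compounds shown alone.

Of the compounds shown here, three have so far been tested in a functional assay on Vero cells (Chlorocebus sabaeus) for cytotoxicity; on this read-out higher numbers stand for weaker inhibition and lower numbers for stronger inhibition: compound 1 `Nc1ccn([C@@H]2CC(F)(F)[C@H](CO)O2)c(=O)n1`, compound 2 `Nc1ccn([C@H]2C=C(F)[C@H](CO)O2)c(=O)n1` and compound 3 `Nc1ncnc2c1ncn2[C@H]1CC(F)(F)[C@H](CO)O1`. Compound 1 gives > 100000 nM, which is a limit of the assay and not a number. Compound 2 gives > 100000 nM, which is also a limit. Compound 3 gives > 100000 nM, again a limit. Compound 3 therefore has no exact value and stands level with the other two, a position summed up as the limit of > 100000 nM in this assay, at which 3 of the 3 values shown sit.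

Compound 4 `OC[C@@H]1O[C@@H](n2cnc3c(O)ncnc32)CC1(F)F` has not yet been measured. It differs from compound 3 in one place: hydroxy in place of amino on an aromatic carbon. In short, it carries hydroxy in place of amino on an aromatic carbon, and the rest of the structure is unchanged.

Among the compounds with values here, no two measured compounds differ in just one place, so the data offer no direct precedent for this swap. Because of the limit of > 100000 nM in this assay, at which 3 of the 3 values shown sit, no step beyond the usual scatter is expected in this assay, in either direction. The expected change, a number no higher from compound 3 to compound 4 (the limit leaves the size open), is accordingly no real shift. For compound 4 the estimated value is 100000 nM, with an expected range of 50000 nM to 200000 nM, and the assay will most likely report only a limit.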

Compound 4, half-maximal inhibitory concentration: > 100000 nM
Compound 4: no number, only a limit; the forecaster's own chance of this, stated with the estimate: 90%; the middle value lies on the limit itself.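

In this assay compound 4 gives > 100000 nM, which is a limit and not a number. No step can be read between compound 3 and compound 4, because both results are limits: the limit of > 100000 nM in this assay, at which 4 of the 4 values shown sit.

The compounds shown leave open whether hydroxy in place of amino on an aromatic carbon changes the result in this assay at all; none of them gives an exact value.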